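The source may report more compounds than this note shows. Statements on the series, on what has been measured and on what is new or still open speak of the compounds shown alone.

Measured in an ADME assay for pharmacokinetics, read by LC-MS, in phosphate buffer, with a stated time of 120 min, at pH 7.4, tested at 1 uM, in the presence of a further agent that is not named here; a higher number here means that the compound lasts longer, a lower number that the compound disappears faster:
compound 1 `C=C(C(=O)Nc1ccccc1)C(F)(F)F`: 0.25 h
compound 2 `O=C(/C=C/C(F)(F)F)Nc1ccccc1`: 0.267 h
compound 3 `CCN(CC)C/C=C/C(=O)Nc1ccccc1`: 2.83 h

In this assay the three compounds fall into two levels. Compound 1 stands at the low end of the numbers, level with compound 2 within the scatter, while compound 3 carries a number well beyond the scatter from both.

Compound 4 `C=C(CCO)C(=O)Nc1ccccc1` has not yet been measured. Set against compound 1, it shows 2-hydroxyethyl in place of trifluoromethyl on a double-bonded chain carbon bound to a carbonyl carbon.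

For the measured compounds named here, no pair of measured compounds differs in one place only, so no direct precedent exists for this change, and the expectation rests on the values alone. Among these three compounds, the two low values belong to those carrying trifluoromethyl, and the one compound without that group, compound 3, reaches 2.83 h. Going by the values given here, with only three compounds, this is a weak guide. On that basis a rise beyond the scatter is expected, with the estimated step being a 20-fold higher number from compound 1 to compound 4 (1.30 log units; beyond the scatter). For compound 4 the half-life is estimated at 5 h, with an expected range from 1.2 h to 20 h.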

Compound 4, half-life: > 8.53 h
Compound 4: no number, only a limit; the forecaster's own chance of this, stated with the estimate: 30%; middle value at least 1.7-fold (0.23 log units) away from the limit.
By their numbers in this assay, from the lowest: compounds 1 and 2 (each within the scatter of the next); then compound 3. At a limit, above all of these: compound 4.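

In this assay, for the compounds shown here, 2-hydroxyethyl in place of trifluoromethyl on a double-bonded chain carbon bound to a carbonyl carbon gives an at least 34-fold higher number from compound 1 to compound 4 (1.53 log units; beyond the scatter), the first step in this set that is read between two compounds differing in one place only. Going by these compounds alone, the earlier compounds offered no such pair, so this step is the first direct sign that this position alone can move the half-life well beyond the scatter, towards a compound that lasts longer. The reading for compound 4 is a limit and not a number, so the step gives only a minimum size: the limit of > 8.53 h in this assay, at which 1 of the 4 values shown sits.

The compounds shown leave open whether the step follows the loss of trifluoromethyl or the arrival of the hydroxyl, a question that a plain ethyl, a methoxyethyl or an aminoethyl chain at this place would help to separate. Also open, as far as these compounds go, are the true half-life of compound 4, which the limit does not give, and whether the same change would bring a step of similar size on a core other than that of compound 1.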